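Benzyl in Place of Cyclohexyl on a Shared Aromatic Nitrogen

A few compounds are considered here, and "the series" means these few. Any claim that something is new, unique, unknown or untested is made for them only; others in the source may bear on it.

Compound 1 `c1ccc2c(-c3cn4ccnc4c(-c4ccc5ncn(C6CCCCC6)c5c4)n3)cccc2c1` and compound 2 `c1ccc(Cn2cnc3ccc(-c4nc(-c5cccc6ccccc56)cn5ccnc45)cc32)cc1` share one core; compound 3 `c1cn2cc(-c3ccc4c(c3)ncn4C3CCCCC3)nc(-c3ccc4ncn(C5CCCCC5)c4c3)c2n1` and the unmeasured compound 4 `c1ccc(Cn2cnc3ccc(-c4nc(-c5ccc6c(c5)ncn6C5CCCCC5)cn5ccnc45)cc32)cc1` share another. How the two cores differ is not broken down here. In a functional assay on UO-31 cells (Homo sapiens) for inhibition, read by sulforhodamine B assay, with a stated time of 48 h, tested at 10 uM (a lower number here means less inhibition, a higher number more inhibition at the concentration tested (going by the name of the read-out)), compound 1 gives 23% and compound 2 gives 31.3%. The change between them, (benzyl in place of cyclohexyl on an aromatic nitrogen), made a step of a number 8.3 percentage points higher from compound 1 to compound 2 (within the scatter). In this assay compound 3 gives 25.6%. Compound 4 carries the same change, (benzyl in place of cyclohexyl on an aromatic nitrogen), at a place described in the same words. Because the earlier step of a number 8.3 percentage points higher from compound 1 to compound 2 (within the scatter) stayed within the scatter, compound 4 is expected to move by about a number 5.4 percentage points higher from compound 3 to compound 4 (within the scatter). The estimate for compound 4 in this assay is 31%, expected to fall between 18% and 44%.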

Compound 4, a percentage reported as inhibition, at one concentration (the size of the read-out at that concentration, not a potency): -51.4%
Compound 4: middle estimate off by 82.4 percentage points, on the high side, and the stated range ends above it.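

In this assay benzyl in place of cyclohexyl on an aromatic nitrogen made a step of a number 77 percentage points lower from compound 3 to compound 4 (beyond the scatter) and did not repeat on the core of compound 3 what it had done on the core of compound 1: the same change on two cores in this assay, a number 8.3 percentage points higher (within the scatter) from compound 1 to compound 2 and a number 77 percentage points lower (beyond the scatter) from compound 3 to compound 4, 85.3 percentage points apart, beyond the scatter of two such steps.

Among the compounds shown here, in this series, then, the step seen on one core was no guide to the step on the other. This does not show which feature of the two cores sets the steps apart, and two steps say nothing about how the change would behave on any further core.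

The compounds shown leave open whether the large step belongs to benzyl itself or would also appear with another group on that nitrogen, such as methyl or a longer chain ending in an amine. They also leave open whether the gap between the two steps would hold at other concentrations or in other cell lines.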